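The source may hold more compounds than are shown below. What is called first, only, known or untested is meant among the compounds shown, and "the series" means these compounds.

Measured so far:
compound 1 `CC(C)NS(=O)(=O)NC(=O)Nc1c(C(C)C)cccc1C(C)C`: 18000 nM
compound 2 `CC(C)c1cccc(C(C)C)c1NC(=O)NS(=O)(=O)N(C(C)C)C1CCCCC1`: 360 nM
compound 3 `CC(C)c1cccc(C(C)C)c1NC(=O)NS(=O)(=O)N(Cc1ccccc1)Cc1ccccc1`: 2200 nM

In an assay on liver for inhibition of sterol O-acyltransferase 1 (Rattus norvegicus), using microsomes (on this read-out lower numbers stand for stronger inhibition and higher numbers for weaker inhibition), compound 3 gives 2200 nM, the second highest of the three numbers; compound 2 gives 360 nM and compound 1 gives 18000 nM. Compound 4 `CC(C)c1cccc(C(C)C)c1NC(=O)NS(=O)(=O)N(Cc1ccccc1)C(C)C` differs from compound 3 by isopropyl in place of benzyl on a sulfonamide nitrogen, so it carries one benzyl and one isopropyl on that nitrogen, which places it between the two benzyls of compound 3 and the isopropyl with cyclohexyl of compound 2. Within the data shown here, the only measured single-place step, a 50-fold lower number from compound 1 to compound 2 (1.70 log units; beyond the scatter), put cyclohexyl in place of hydrogen, a different change, so it gives no direct guide. Compound 2 and compound 3 differ in two places and show the lower number for compound 2. The step of a 2.4-fold lower number from compound 3 to compound 4 (0.39 log units; beyond the scatter) is therefore expected to be modest, toward a lower number. Compound 4 is estimated at 900 nM, between 300 nM and 2700 nM.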

Compound 4, half-maximal inhibitory concentration: 400 nM
For compound 4 the middle estimate is 2.3-fold (0.35 log units) above the measured one; the measured number falls inside the stated range.
By their numbers in this assay, from the lowest: compounds 2 and 4 (each within the scatter of the next); then compound 3; then compound 1.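

In this assay, isopropyl in place of benzyl on a sulfonamide nitrogen gives a 5.5-fold lower number from compound 3 to compound 4 (0.74 log units; beyond the scatter), so the second benzyl is not needed at this position. With isopropyl as the partner group, benzyl in place of cyclohexyl gives a 1.1-fold higher number from compound 2 to compound 4 (0.05 log units; within the scatter), so these two rings are not told apart here. Benzyl in place of hydrogen gives a 45-fold lower number from compound 1 to compound 4 (1.65 log units; beyond the scatter), showing that a large gain can be reached with either ring.

Whether methyl or a longer chain on this nitrogen would do as well stays open, and nothing measured here explains these steps.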